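Sulfonyl aryl replacement in the trifluoromethyl hydroxyamide series

The source may hold more compounds than are shown below. What is called first, only, known or untested is meant among the compounds shown, and "the series" means these compounds.

Compound 1, `CC(O)(C(=O)Nc1cccc(S(=O)(=O)c2ccccc2)c1)C(F)(F)F`, in a functional assay (Cavia porcellus) with sulfonylurea receptors; K-ATP channels (Homo sapiens) as the target (a higher number here means a weaker inhibitor, a lower number a stronger inhibitor), gives > 30000 nM, a limit of the assay.
Compound 2, `CC(O)(C(=O)Nc1ccc(C#N)c(S(=O)(=O)c2ccccc2)c1)C(F)(F)F`, in this assay gives 2600 nM.
Compound 3, `CC(O)(C(=O)Nc1ccc(S(=O)(=O)c2ccc(C#N)cc2)cc1)C(F)(F)F`, in this assay gives > 30000 nM, a limit of the assay.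

Compound 3 stands at the limit of > 30000 nM in this assay, at which 2 of the 3 values shown sit, so no number is known for it. Compound 4, `CC(O)(C(=O)Nc1ccc(S(=O)(=O)c2nccs2)cc1)C(F)(F)F`, differs from it by 1,3-thiazol-2-yl in place of 4-cyanophenyl on a sulfonyl sulfur. Among the measured compounds shown here, the one measured step, an at least 11-fold lower number from compound 1 to compound 2 (1.06 log units; beyond the scatter), concerns a change elsewhere in the molecule, not the group on the sulfonyl sulfur, so it does not bear directly on this change; nothing measured tells what replacing the group on the sulfonyl sulfur does. With compound 3 at a limit, no step beyond the scatter can be expected in either direction; compound 4 is expected to give only a limit again, a number no higher from compound 3 to compound 4 (the limit leaves the size open). Compound 4 is estimated at 30000 nM, between 8000 nM and 100000 nM.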

Compound 4, half-maximal inhibitory concentration: 1400 nM
Compound 4: the middle estimate sits 21-fold (1.33 log units) above what was measured, and the stated range ends above it.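

The group on the sulfonyl sulfur clearly affects the read-out in this assay: 1,3-thiazol-2-yl in place of 4-cyanophenyl gives an at least 21-fold lower number from compound 3 to compound 4 (1.33 log units; beyond the scatter). This is the only step shown at this position, and it brings a compound without the cyano change of compound 2 into a measurable range. Compound 3 sits at a limit, so the full size of the step stays open: the limit of > 30000 nM in this assay, at which 2 of the 4 values shown sit.

Which part of the exchange carries the step remains open: the ring size, the hetero atoms or the loss of the nitrile. Also open, from the compounds shown here alone, is whether pyridin-2-yl or 1,3-oxazol-2-yl on the sulfonyl sulfur would behave like 1,3-thiazol-2-yl.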